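The source may hold more compounds than are shown below. What is called first, only, known or untested is meant among the compounds shown, and "the series" means these compounds.

Series notes. The four compounds share one core; compound 1 is `CC1CCN(C2CCN(S(=O)(=O)c3cccc(C(F)(F)F)c3)CC2)CC1`, compound 2 is `CC1CCN(C2CCN(S(=O)(=O)c3cccnc3Cl)CC2)CC1`, compound 3 is `CC1CCN(C2CCN(S(=O)(=O)c3cccnc3)CC2)CC1`, and compound 4, not yet measured, is `CC1CCN(C2CCN(S(=O)(=O)c3ccc(Cl)c(C(F)(F)F)c3)CC2)CC1`. The difference between the cores of compound 1 and compound 3 is not broken down here.

In a functional assay on DLD-1 cells (Homo sapiens) for antiproliferative activity, read by CellTiter-Glo, with a stated time of 72 h (on this read-out lower numbers stand for stronger inhibition and higher numbers for weaker inhibition), compound 3 gives 2400 nM. For compound 2 the read-out is a limit of the assay, > 5000 nM. For compound 1 the read-out is likewise a limit, > 5000 nM. Two of the three values sit at the limit of > 5000 nM in this assay, at which 2 of the 3 values shown sit.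

Among the compounds with values here, the one measured step, (chloro in place of hydrogen on an aromatic carbon), gives an at least 2.0-fold higher number from compound 3 to compound 2 (0.31 log units; beyond the scatter). The change from compound 1 to compound 4, (chloro in place of hydrogen on an aromatic carbon), is the same kind of change, but not the same: in compound 2 the chlorine sits on a six-membered aromatic ring with one nitrogen, next to the ring nitrogen and ortho to a large group, whereas in compound 4 it sits on a six-membered aromatic ring of carbon only, ortho to a trifluoromethyl group and para to a large group.

Compound 1 already stands at a limit in this assay with > 5000 nM. No gain is expected for compound 4 because an at least 2.0-fold higher number from compound 3 to compound 2 (0.31 log units; beyond the scatter) ran toward weaker inhibition on the core of compound 3. For compound 4 in this assay the expected step is a step that the limit leaves unreadable from compound 1 to compound 4. Compound 4 is expected to give about 8000 nM, most likely again only a limit, with an expected range from 3000 nM to 25000 nM.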

Compound 4, half-maximal inhibitory concentration: 17 nM
Compound 4: the middle estimate sits 470-fold (2.67 log units) above what was measured; measured number below the stated range.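

In this assay, chloro in place of hydrogen on an aromatic carbon gives an at least 290-fold lower number from compound 1 to compound 4 (2.46 log units; beyond the scatter), so on the core of compound 1 this single change separates a read-out at a limit of the assay from the most clearly measured value in the series. The change therefore cannot be carried from one core to another in this series as a fixed increment, since the two pairs shown do not even agree in direction: the same change on two cores in this assay, an at least 2.0-fold higher number (0.31 log units; beyond the scatter) from compound 3 to compound 2 and an at least 290-fold lower number (2.46 log units; beyond the scatter) from compound 1 to compound 4, at least 610-fold (2.78 log units) apart, beyond the scatter of two such steps What this does not show is which difference between the two cores sets the outcome, or how large either step really is, as two pairs cannot settle the first and each step has one end at a limit: the limit of > 5000 nM in this assay, at which 2 of the 4 values shown sit.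

Still open, going by these compounds, is whether the chloro of compound 4 depends on the neighbouring trifluoromethyl group, or would give a similar read-out on a carbon-only ring without it. Also open, on these data alone, is whether bromo, methyl or a nitrile in the same place would match the chloro, and whether the step would hold on further cores carrying a ring nitrogen.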